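Sulfonamide series: expectation for compound 4

The compounds below may be only part of what the source reports. "The series", "measured", "known", "first", "only" and "open" are said of these compounds alone.

Measured compounds:
compound 1 `CCCN(CCC)c1c([N+](=O)[O-])cc(S(=O)(=O)Nc2ccc(C)cc2)cc1[N+](=O)[O-]` — in a functional assay on PC-3 cells (Mus musculus) for cytotoxicity against PC-3 (Homo sapiens) (on this read-out lower numbers stand for stronger inhibition and higher numbers for weaker inhibition), compound 1 gives 21000 nM
compound 2 `CCCN(CCC)c1c([N+](=O)[O-])cc(S(=O)(=O)Nc2ccc(Cl)cc2)cc1[N+](=O)[O-]` — in this assay compound 2 gives 16000 nM
compound 3 `CCCN(CCC)c1c([N+](=O)[O-])cc(S(=O)(=O)Nc2cccc(OC)c2)cc1[N+](=O)[O-]` — in this assay compound 3 gives 36000 nM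

Compound 2 carries the lowest of the three numbers in this assay, but compound 1 sits within the scatter of it: a 1.3-fold lower number from compound 1 to compound 2 (0.12 log units; within the scatter), so the two cannot be ordered. Compound 3 lies furthest away, a 2.3-fold higher number from compound 2 to compound 3 (0.35 log units; beyond the scatter), a modest step beyond the scatter, whereas a 1.7-fold higher number from compound 1 to compound 3 (0.23 log units; within the scatter) remains within it.

Compound 4 `CCCN(CCC)c1c([N+](=O)[O-])cc(S(=O)(=O)Nc2cccc(Cl)c2)cc1[N+](=O)[O-]` is unmeasured. Against compound 2 the change is 3-chlorophenyl in place of 4-chlorophenyl on a sulfonamide nitrogen; the two compounds share all atoms, joined differently. Within the data shown here, no measured step rearranges a chloro substituent on its own. The nearest guides are the steps into compound 3, in which the group on the phenyl differs in more than one respect: a 2.3-fold higher number from compound 2 to compound 3 (0.35 log units; beyond the scatter) and a 1.7-fold higher number from compound 1 to compound 3 (0.23 log units; within the scatter). Both point at most to a slightly higher number, and a 1.3-fold lower number from compound 1 to compound 2 (0.12 log units; within the scatter) shows that chloro in place of methyl barely matters. For compound 4 the expected step is a 1.4-fold higher number from compound 2 to compound 4 (0.14 log units; within the scatter), a small rise that may well stay within the scatter. Compound 4 is therefore estimated at 22000 nM in this assay, with a range from 10000 nM to 48000 nM.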

Compound 4, half-maximal inhibitory concentration: 18000 nM
Estimate against measurement, compound 4: 1.2-fold (0.09 log units) above, and the stated range covers the measured number.
By their numbers in this assay, from the lowest: compounds 2, 4, 1 and 3 (each within the scatter of the next, the first and the last beyond it).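

In this assay, among these compounds, 3-chlorophenyl in place of 4-chlorophenyl on the sulfonamide nitrogen gives a 1.1-fold higher number from compound 2 to compound 4 (0.05 log units; within the scatter) and so isolates the placement of the chloro for the first time, with no effect that can be read at these two positions. Chloro in place of methoxy on an aromatic carbon gives a 2.0-fold lower number from compound 3 to compound 4 (0.30 log units; within the scatter) and 3-chlorophenyl in place of 4-methylphenyl gives a 1.2-fold lower number from compound 1 to compound 4 (0.07 log units; within the scatter) so compound 4 stays within the scatter of all three earlier compounds, and the modest step from compound 2 to compound 3 cannot be assigned to a 3-substituted phenyl as such. No measurement in hand explains why the placement of the chloro leaves the number unresolved.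

All four compounds remain within a narrow band of values and carry only small neutral groups on the phenyl, so the response of this position to an amine or a carboxylic acid is open. Whether a longer chain on the aniline ring would separate the compounds in this assay also stays unanswered.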